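Aryl hydrazone variation on the shared core

The compounds below may be only part of what the source reports. "The series", "measured", "known", "first", "only" and "open" are said of these compounds alone.

Measured so far:
- compound 1 `CN(C)CCn1cnnc1-c1cc(Oc2ccc(NC(=O)N/N=C/c3cc(Br)c(O)c(Br)c3)cc2F)ccn1` gives 3760 nM in a functional assay on NCI-H460 cells (Homo sapiens) for cytotoxicity, read by MTT assay, with a stated time of 72 h; a lower number here means a stronger inhibitor, a higher number a weaker inhibitor
- compound 2 `COc1cc(/C=N/NC(=O)Nc2ccc(Oc3ccnc(-c4nncn4CCN(C)C)c3)c(F)c2)ccc1O` gives 57 nM in this assay

Compound 2 stands at the lowest of the two numbers; its nearest neighbour is compound 1, and the step of a 66-fold lower number from compound 1 to compound 2 (1.82 log units; beyond the scatter) is large and well beyond the scatter. That step is the only one measured, and it shows that the aryl group on the carbon double-bonded to nitrogen moves the read-out strongly.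

Compound 3 `CN(C)CCn1cnnc1-c1cc(Oc2ccc(NC(=O)N/N=C/c3ccc(O)cc3O)cc2F)ccn1` is not yet measured. It differs from compound 2 by 2,4-dihydroxyphenyl in place of 4-hydroxy-3-methoxyphenyl on a carbon with a double bond to nitrogen. The 4-hydroxy group is kept, the 3-methoxy group is lost and a second hydroxy group enters. Among the measured compounds shown here, no measured pair shows exactly this exchange, so the step from compound 1 to compound 2 is only an indirect guide: it says the position is sensitive, not which way a second hydroxy group will push. A moderate rise from compound 2 is expected, since compound 2 holds the lowest number and any drift is more likely upward. The expected step is a 3.5-fold higher number from compound 2 to compound 3 (0.55 log units; beyond the scatter). For compound 3 the estimate in this assay is 200 nM, with a range from 50 nM to 1000 nM.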

Compound 3, half-maximal inhibitory concentration: 11300 nM
For compound 3 the middle estimate is 57-fold (1.75 log units) below the measured one, and the stated range ends below it.
By their numbers in this assay, from the lowest: compound 2; then compound 1; then compound 3.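

In this assay, the 4-hydroxy group alone does not secure a low number at this position: all three aryl groups on the carbon with a double bond to nitrogen carry it, yet the change to 2,4-dihydroxyphenyl gives a 200-fold higher number from compound 2 to compound 3 (2.30 log units; beyond the scatter), a large loss that compound 1 shares in part. The bromine-bearing aryl group is also not the poorest of the three, since the exchange of 3,5-dibromo-4-hydroxyphenyl for 2,4-dihydroxyphenyl gives a 3.0-fold higher number from compound 1 to compound 3 (0.48 log units; beyond the scatter), a modest step beyond the scatter, so among these compounds only the 4-hydroxy-3-methoxyphenyl of compound 2 stands apart. No supporting data bear on why this aryl exchange acts so strongly.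

The exchange from compound 2 to compound 3 removes a methoxy group and adds a hydroxy group in one step, so the compounds shown cannot separate the part played by each. Open too, from the compounds shown here alone, is how this position responds to groups of another kind, such as a dimethylamino group, a carboxylic acid or a plain unsubstituted phenyl ring.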